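The source may hold more compounds than are shown below. What is called first, only, known or untested is meant among the compounds shown, and "the series" means these compounds.

Compound 1 `O=[N+]([O-])c1cccc(CNc2cc(Br)cc3[nH]ncc23)c1` gives 91%.
Compound 2 `O=[N+]([O-])c1cccc(CNc2cc(C(F)(F)F)cc3[nH]ncc23)c1` gives 60%.
Compound 3 `O=[N+](O)c1c(Cl)cccc1CNc1cc(C(F)(F)F)cc2[nH]ncc12` gives 96%.

These three values come from an assay for inhibition of Tryptophan 2,3-dioxygenase (Homo sapiens), with stated times of 10 min and 60 min, tested at 10 uM; on this read-out higher numbers stand for a stronger effect at the one concentration tested and lower numbers for a weaker effect. Among the measured compounds shown here, compound 2 stands lowest of the three: compound 1 lies closest above it, and the only measured one-place step, a number 31 percentage points lower from compound 1 to compound 2 (beyond the scatter), is the one that brings the number down to where compound 2 sits. Compound 3, which differs from compound 2 in more than one place, gives the highest value of the three.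

Compound 4 `FC(F)(F)c1cc(NCc2cccc(Br)c2)c2cn[nH]c2c1` is not yet measured. It differs from compound 2 in one place: bromo in place of nitro on an aromatic carbon. The change sits on the six-membered aromatic ring of carbon only, meta to a large group.

For the measured compounds named here, no measured step bears on this change. Going by the values given here, the single step known concerns the other ring and a different pair of groups, so it gives no guide to swapping nitro for bromo here. With nothing to lean on, the honest expectation in this assay is a step of about a number 5 percentage points lower from compound 2 to compound 4 (within the scatter), which is to say no step beyond the scatter, with a wide band either side. Compound 4 is therefore estimated at 55%, with a range from 25% to 85%.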

Compound 4, a percentage reported as inhibition, at one concentration (the size of the read-out at that concentration, not a potency): 67%
Beside the measured number, compound 4's estimate is 12 percentage points below it; low and high end bracket the measured number.
By their numbers in this assay, from the lowest: compounds 2 and 4 (each within the scatter of the next); then compounds 1 and 3 (each within the scatter of the next).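

In this assay, putting bromo in place of nitro on the six-membered aromatic ring of carbon only gives a number 7 percentage points higher from compound 2 to compound 4 (within the scatter), so the three heavy atoms of the nitro group, with its two hydrogen-bond acceptors, can give way to a single bromine without a step beyond the scatter. Among the compounds shown here, the earlier step, a number 31 percentage points lower from compound 1 to compound 2 (beyond the scatter), concerned a different place and a different pair of groups and lay beyond the scatter, so this is the first view of how this ring position responds to a change. No measurement at hand gives a reason for this outcome.

These compounds leave open whether other groups at this position, such as a nitrile, a carboxylic acid or an amine, would also leave the number within the scatter, or whether the tolerance seen here is special to bromo. Going by these compounds, it is also open whether the same swap would read alike on the core of compound 1, where bromo stands in place of trifluoromethyl, since a single pair cannot show whether the result holds beyond this one core.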